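Piperazine dithiocarbamate anilides: pyrimidinyl for pyridinylmethyl

A few compounds are considered here, and "the series" means these few. Any claim that something is new, unique, unknown or untested is made for them only; others in the source may bear on it.

Compound 1 `Nc1ccccc1NC(=O)c1ccc(CSC(=S)N2CCN(Cc3ccccn3)CC2)cc1` and compound 2 `CC1CCN(C(=S)SCc2ccc(C(=O)Nc3ccccc3N)cc2)CC1` share a core and have both been run in a functional assay on A-375 cells (Homo sapiens) for antiproliferative activity, read by CCK-8 assay, with a stated time of 72 h, tested at 8 uM; a higher number here means a stronger effect of the compound at the concentration tested, a lower number a weaker effect. Compound 1 gives 82.4%; compound 2 gives 87.4%. On the numbers shown compound 1 is the lower of two, but its gap to compound 2 lies within the scatter and is not read as a difference. Compound 3 `Nc1ccccc1NC(=O)c1ccc(CSC(=S)N2CCN(c3ncccn3)CC2)cc1` is not yet measured; it differs from compound 1 thus: pyrimidin-2-yl in place of (pyridin-2-yl)methyl on an amine nitrogen in a ring. Among the measured compounds shown here, no measured pair shows a step of this kind, so its direction is open; in this assay no step beyond the scatter is expected. Compound 3 is estimated at 80%, between 65% and 92%. The expected step of a number 2.4 percentage points lower from compound 1 to compound 3 (within the scatter) is small.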

Compound 3, a percentage reported as inhibition, at one concentration (the size of the read-out at that concentration, not a potency): 67.9%
The estimate for compound 3 lay 12.1 percentage points above the measured number, and the stated range covers the measured number.
By their numbers in this assay, from the lowest: compound 3; then compounds 1 and 2 (each within the scatter of the next).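

In this assay, among the compounds shown here, this amine nitrogen in the ring is not indifferent to its substituent: pyrimidin-2-yl in place of (pyridin-2-yl)methyl gives a number 14.5 percentage points lower from compound 1 to compound 3 (beyond the scatter), the first step beyond the scatter. The change alters the aromatic ring and removes the methyl link in one step, so the two contributions cannot be separated. No measured evidence bears on the cause of this step.

A directly attached pyridin-2-yl or a (pyrimidin-2-yl)methyl group would separate the two contributions. The read-out at one concentration leaves any difference in potency open.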